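A few compounds are considered here, and "the series" means these few. Any claim that something is new, unique, unknown or untested is made for them only; others in the source may bear on it.

Measured so far:
compound 1, `Cc1c(C(=O)N/N=C\c2c(O)cccc2Cl)oc2cccc(O)c12`: 18700 nM
compound 2, `Cc1c(C(=O)N/N=C\c2cc(Cl)cc(Cl)c2O)oc2cccc(O)c12`: 9590 nM
compound 3, `Cc1c(C(=O)N/N=C\c2cccc(Br)c2O)oc2cccc(O)c12`: 16600 nM

In a functional assay on PC-3 cells (Homo sapiens) for inhibition (on this read-out higher numbers stand for weaker inhibition and lower numbers for stronger inhibition), compound 1 gives the highest of the three numbers, but its distances to compound 3 and to compound 2 are both within the scatter, so no ordering among them can be read from these values. Compound 4, `Cc1c(C(=O)N/N=C\c2cccc(F)c2O)oc2cccc(O)c12`, differs from compound 1 as follows: 3-fluoro-2-hydroxyphenyl in place of 2-chloro-6-hydroxyphenyl on a carbon with a double bond to nitrogen. Among the compounds with values here, the one step that bears on this is the related change from compound 1 to compound 3, which gave a 1.1-fold lower number from compound 1 to compound 3 (0.05 log units; within the scatter). Since that exchange of halogen and hydroxyl placement left the number essentially unchanged, no step beyond the scatter is expected here either. Compound 4 is therefore estimated at 17000 nM, within 8000 nM to 36000 nM, meaning an expected 1.1-fold lower number from compound 1 to compound 4 (0.04 log units; within the scatter).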

Compound 4, half-maximal inhibitory concentration: 12700 nM
Beside the measured number, compound 4's estimate is 1.3-fold (0.13 log units) above it; low and high end bracket the measured number.
By their numbers in this assay, from the lowest: compounds 2, 4, 3 and 1 (each within the scatter of the next).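

Swapping the halogen alone now gives a 1.3-fold lower number from compound 3 to compound 4 (0.12 log units; within the scatter) in this assay, and the wider change gives a 1.5-fold lower number from compound 1 to compound 4 (0.17 log units; within the scatter), so both steps stay within the scatter. Fluoro and bromo on this aromatic carbon therefore cannot be told apart by this read-out, and the halogens shown so far give no readable change. No supporting measurement accounts for these numbers. Still open, as far as these compounds go, is whether a non-halogen group on that carbon, such as an amine or a carboxylic acid, would produce a step beyond the scatter.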